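Arylpiperazine to furoyl amide: a step from an unreadable baseline

The source may hold more compounds than are shown below. What is called first, only, known or untested is meant among the compounds shown, and "the series" means these compounds.

Compound 1 `COc1ccc(S(=O)(=O)NCCCN2CCN(c3ccccc3)CC2)cc1` and compound 2 `COc1ccc(S(=O)(=O)NCCCN2CCN(c3ccc(C(C)=O)cc3)CC2)cc1` share one core. In an assay on CHO cells for displacement of a labelled ligand from 5-hydroxytryptamine receptor 7 (Homo sapiens) (on this read-out higher numbers stand for weaker inhibition and lower numbers for stronger inhibition), compound 1 reaches only the limit of the assay, > 10000 nM. Compound 2 likewise reaches only the limit, > 10000 nM. The change a step that the two limits leave unreadable from compound 1 to compound 2 therefore cannot be sized, since both values sit at the limit of > 10000 nM in this assay, at which 2 of the 2 values shown sit. Compound 3 `COc1ccc(S(=O)(=O)NCCCN2CCN(C(=O)c3ccco3)CC2)cc1` carries a different change: (furan-2-yl)carbonyl in place of 4-acetylphenyl on an amine nitrogen in a ring. Among the measured compounds shown here, no measured step speaks to this replacement, and compound 2 offers only a limit to build on. The step that the limit leaves unreadable from compound 2 to compound 3 is expected to leave the value at the limit as well. Compound 3 is estimated at 20000 nM, between 5000 nM and 100000 nM.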

Compound 3, half-maximal inhibitory concentration: > 10000 nM
Compound 3: only a limit was reported; the forecaster's own chance of this, stated with the estimate: 85%; the middle value does not contradict the limit.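

Compound 3 also gives only a limit, so no step among compound 1, compound 2 and compound 3 can be read: the limit of > 10000 nM in this assay, at which 3 of the 3 values shown sit.

The compounds shown leave open how phenyl, 4-acetylphenyl and (furan-2-yl)carbonyl on the ring's amine nitrogen truly compare in this assay.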